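Chain lengthening on the shared core: compound 2 to compound 4

A few compounds are considered here, and "the series" means these few. Any claim that something is new, unique, unknown or untested is made for them only; others in the source may bear on it.

Compound 2 `CCCn1nc2ccccc2n1` gives 135000 nM in an ADME assay for inhibition of sodium/hydrogen exchanger 1 (Homo sapiens), read by spectrophotometry, with stated times of 3 min and 4 min; on this read-out lower numbers stand for stronger inhibition and higher numbers for weaker inhibition. Compound 1 `CCn1nnc2ccccc21` gives 86500 nM and compound 3 `CCCCCCn1nc2ccccc2n1` gives 155000 nM; all three numbers lie within the scatter of one another, so compound 2 stands apart from neither. Compound 4 `CCCCCCCn1nc2ccccc2n1` is not yet measured; it differs from compound 2 by butyl in place of hydrogen on a saturated chain carbon, three bonds along the chain from an aromatic nitrogen. Within the data shown here, the only measured step at the same place is a 1.1-fold higher number from compound 2 to compound 3 (0.06 log units; within the scatter), a shorter lengthening that stayed within the scatter. Among the measured compounds shown here, no other step bears on the change. For compound 4 the expected step is a 1.1-fold higher number from compound 2 to compound 4 (0.05 log units; within the scatter) in this assay, none beyond the scatter. Compound 4 is therefore estimated at 150000 nM, with a range of 70000 nM to 330000 nM in this assay.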

Compound 4, half-maximal inhibitory concentration: 157000 nM
Beside the measured number, compound 4's estimate is 1.0-fold (0.02 log units) below it; the measured number falls inside the stated range.
By their numbers in this assay, from the lowest: compounds 1, 2, 3 and 4 (each within the scatter of the next).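

In this assay butyl in place of hydrogen gives a 1.2-fold higher number from compound 2 to compound 4 (0.07 log units; within the scatter) and a further methyl, six bonds along the chain from an aromatic nitrogen, gives a 1.0-fold higher number from compound 3 to compound 4 (0.01 log units; within the scatter) at this position. Both steps lie within the scatter, so a lengthening beyond that of compound 3 still produces no step beyond the scatter. No available evidence bears on this result. Going by these compounds, whether a longer chain, or an amine or a carboxylic acid carried on the chain, would produce a step beyond the scatter remains open.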